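Replacing 2-methoxyphenyl with 1H-pyrazol-1-yl: an expected outcome

The compounds below may be only part of what the source reports. "The series", "measured", "known", "first", "only" and "open" are said of these compounds alone.

In a functional assay on G-361 cells (Homo sapiens) for inhibition, with a stated time of 72 h (on this read-out higher numbers stand for weaker inhibition and lower numbers for stronger inhibition), compound 1 `COc1ccccc1-c1ccc(CNc2nc(NC3CCC(N)CC3)nc3c2ncn3C2CCCC2)cc1` gives 545 nM. Compound 3 `NC1CCC(Nc2nc(NCc3ccc(-c4ccsc4)cc3)c3ncn(C4CCCC4)c3n2)CC1` gives 570 nM, level with compound 1, while compound 2 `NC1CCC(Nc2nc(NCc3ccc(-c4ccco4)cc3)c3ncn(C4CCCC4)c3n2)CC1` gives 164 nM, the lowest of the three. Compound 4 `NC1CCC(Nc2nc(NCc3ccc(-n4cccn4)cc3)c3ncn(C4CCCC4)c3n2)CC1` is still unmeasured. It carries 1H-pyrazol-1-yl in place of 2-methoxyphenyl on an aromatic carbon. Two measured replacements of the same group bear on this change. Furan-2-yl gives a 3.3-fold lower number from compound 1 to compound 2 (0.52 log units; beyond the scatter), whereas thiophen-3-yl gives a 1.0-fold higher number from compound 1 to compound 3 (0.02 log units; within the scatter). These outcomes differ, with a 3.5-fold higher number from compound 2 to compound 3 (0.54 log units; beyond the scatter), so neither alone settles the case, and an outcome between them seems reasonable. The expected step is a 1.8-fold lower number from compound 1 to compound 4 (0.26 log units; within the scatter), which would be a small move toward stronger inhibition at most. For compound 4 the estimated value is 300 nM, with an expected range from 110 nM to 800 nM.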

Compound 4, half-maximal inhibitory concentration: 220 nM
For compound 4 the middle estimate is 1.4-fold (0.13 log units) above the measured one; the measured number falls inside the stated range.
By their numbers in this assay, from the lowest: compounds 2 and 4 (each within the scatter of the next); then compounds 1 and 3 (each within the scatter of the next).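

Compound 4 shows that 1H-pyrazol-1-yl at this place gives a 2.5-fold lower number from compound 1 to compound 4 (0.39 log units; beyond the scatter) and a 2.6-fold lower number from compound 3 to compound 4 (0.41 log units; beyond the scatter), so a second five-membered aromatic ring joins furan-2-yl on the low side of the series. With a 1.3-fold higher number from compound 2 to compound 4 (0.13 log units; within the scatter), compounds 2 and 4 stand level, while compound 3 goes against any rule that a five-membered aromatic ring alone lowers the number. Nothing shown explains why these rings differ. From the compounds shown here alone, whether a carboxylic acid or an amine at this place would also keep the number low remains open.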